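The compounds below may be only part of what the source reports. "The series", "measured", "known", "first", "only" and "open" are said of these compounds alone.

Compound 1, with the structure `O=C(COc1cccc2ccccc12)N/N=C/c1ccc(O)cc1`, was tested in an ADME assay on HEL cells (Homo sapiens) for cytotoxicity (a lower number here means that less compound is tolerated, a higher number that more compound is tolerated), where compound 1 gives 60.6 ug/mL. Its companion compound 2, with the structure `C/C(=N\NC(=O)COc1cccc2ccccc12)c1ccc(O)cc1O`, gives in this assay a value of 74.8 ug/mL; the two values lie within the scatter of each other, so nothing can be said of an order between compound 1 and compound 2. Compound 1 is thus the starting point for the step to compound 3, whose structure is `CSc1ccc(/C=N/NC(=O)COc2cccc3ccccc23)cc1` and which has not yet been measured in this assay.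

The change from compound 1 to compound 3 is methylsulfanyl in place of hydroxy on an aromatic carbon. The hydroxy that leaves sits on an aromatic carbon of a six-membered aromatic ring of carbon only, para to a large group, and methylsulfanyl takes its place there. Within the data shown here, no measured pair in this set carries the same change, so there is no step to lean on.

With only compound 1 and compound 2 to go by, and those two within the scatter of each other, the step from compound 1 to compound 3 is expected to be small, a 1.1-fold lower number from compound 1 to compound 3 (0.04 log units; within the scatter), in no particular direction beyond the scatter. For compound 3 the value in this assay is therefore estimated at 55 ug/mL, within a range from 25 ug/mL to 110 ug/mL.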

Compound 3, half-maximal cytotoxic concentration: > 100 ug/mL
Compound 3 gave a limit, no number; the forecaster's own chance of this, stated with the estimate: 15%; at least 1.8-fold (0.25 log units) between middle value and limit.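

In this assay, compound 3 gives > 100 ug/mL, which is a limit of the assay and not a number. The step reads as an at least 1.6-fold higher number from compound 1 to compound 3 (0.21 log units; that floor lies within the scatter), so at this place, on an aromatic carbon para to a large group, methylsulfanyl in place of hydroxy shows no sign of lowering the number, and the hydroxy, with its hydrogen-bond donor, is not needed to hold the value in this assay; since the floor of the step lies within the scatter, a real rise is not established either. This single reading is also the only one in the set that reaches the limit, so the size of the step stays unknown: the limit of > 100 ug/mL in this assay, at which 1 of the 3 values shown sits.

The compounds shown leave open how far the true value of compound 3 lies from that of compound 1, and whether the sulfur, the methyl or simply the loss of the hydroxy matters for the result. They also leave open whether methoxy, an amine or a carboxylic acid at this same place would behave like hydroxy or like methylsulfanyl.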